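This account rests on a few compounds, and the source may have more. Where it says the series, first, only, none or still open, it means among the compounds named here.

Compound 1, `COc1ccc(Oc2ccccc2-c2ccsc2S(=O)(=O)NCCNC(=S)Nc2cc(C(F)(F)F)cc(C(F)(F)F)c2)cc1OC`, is measured in an ADME assay on HEK-293T cells (Homo sapiens) for cytotoxicity, read by CCK-8 assay, with a stated time of 48 h (a higher number here means a weaker inhibitor, a lower number a stronger inhibitor), where compound 1 gives 6800 nM. Compound 2, `COc1ccc(Oc2ccc(C(C)C)cc2-c2ccsc2S(=O)(=O)NCCNC(=S)Nc2cc(C(F)(F)F)cc(C(F)(F)F)c2)cc1OC`, carries isopropyl in place of hydrogen on an aromatic carbon and in this assay compound 2 gives 10200 nM, a step of a 1.5-fold higher number from compound 1 to compound 2 (0.18 log units; within the scatter). Compound 3, `O=C(NCCNS(=O)(=O)c1sccc1-c1ccccc1Oc1ccc(O)c(O)c1)Nc1cc(C(F)(F)F)cc(C(F)(F)F)c1`, belongs to a second core; the difference between the two cores is not broken down here, and in this assay compound 3 gives 8900 nM, which stands within the scatter of both compound 1 and compound 2. Compound 4, `CC(C)c1ccc(Oc2ccc(O)c(O)c2)c(-c2ccsc2S(=O)(=O)NCCNC(=O)Nc2cc(C(F)(F)F)cc(C(F)(F)F)c2)c1`, is not yet measured and differs from compound 3 by isopropyl in place of hydrogen on an aromatic carbon. This is the same kind of change as that from compound 1 to compound 2, but the place differs: here it is para to a 3,4-dihydroxyphenoxy group rather than para to a 3,4-dimethoxyphenoxy group. For compound 4 a step of a 1.5-fold higher number from compound 3 to compound 4 (0.16 log units; within the scatter) is expected because a 1.5-fold higher number from compound 1 to compound 2 (0.18 log units; within the scatter) was small. Compound 4 is therefore estimated at 13000 nM in this assay, within 6000 nM to 28000 nM.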

Compound 4, half-maximal inhibitory concentration: > 20000 nM
Compound 4: a limit, no number; the forecaster's own chance of this, stated with the estimate: 10%; at least 1.5-fold (0.18 log units) between middle value and limit.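

In this assay, isopropyl in place of hydrogen on an aromatic carbon of the second core gives an at least 2.2-fold higher number from compound 3 to compound 4 (0.35 log units; beyond the scatter). Compound 4 gives > 20000 nM, which is a limit of the assay and not a number. This shows a step beyond the scatter on this core, but it does not show whether the change carries over from one core to the other with the same size: the same change on two cores in this assay, a 1.5-fold higher number (0.18 log units; within the scatter) from compound 1 to compound 2 and an at least 2.2-fold higher number (0.35 log units; beyond the scatter) from compound 3 to compound 4; the limit leaves it open whether they differ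

The compounds shown leave open what methyl or an amine on that same aromatic carbon would do in this assay. They also leave open how large the isopropyl step on the second core really is.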